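The source may hold more compounds than are shown below. What is called first, only, known or untested is meant among the compounds shown, and "the series" means these compounds.

Of the compounds shown here, three have been measured in a functional assay for agonist activity at G protein-coupled receptor 88 (Homo sapiens), read by HTRF and cAMP accumulation; a higher number here means that more compound is needed for the effect, a lower number that less compound is needed. Compound 1 `CC(C)C[C@H](N)CCN(C(=O)[C@@H]1C[C@H]1c1ccccc1)c1ccc(-c2ccccc2)cc1` gives 3 nM in this assay, and compound 2 `CC(C)CCNCCN(C(=O)[C@@H]1C[C@H]1c1ccccc1)c1ccc(-c2ccccc2)cc1` gives 5.1 nM. Within the data shown here, the only step between neighbouring measured compounds, a 1.7-fold higher number from compound 1 to compound 2 (0.23 log units; within the scatter), alters the amine-bearing chain and leaves the rest of the molecule untouched. Compound 3 `CC[C@H](C)[C@H](N)CN(C(=O)[C@@H]1C[C@H]1c1ccc(F)cc1)c1ccc(-c2ccccc2)cc1`, which carries a 4-fluorophenyl on its three-membered ring and yet another amine chain, gives 600 nM in this assay, the highest number of the three and well beyond the scatter from both compound 1 and compound 2.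

Compound 4 `CC[C@H](C)[C@H](N)CN(C(=O)[C@@H]1C[C@H]1c1cc(F)ccc1F)c1ccc(-c2ccccc2)cc1` differs from compound 3 in a single place: 2,5-difluorophenyl in place of 4-fluorophenyl on a saturated ring carbon. Among the measured compounds shown here, no measured pair bears on this change; the one recorded step concerns the amine chain, not the fluorine pattern on the aromatic ring, so the data give no direction for it. With nothing to push the number up or down, the plain expectation is that compound 4 stays close to compound 3. Compound 4 is therefore expected to give about 600 nM in this assay, within a range from 150 nM to 2400 nM. This amounts to an expected step of no change at the digits printed from compound 3 to compound 4 (within the scatter), no larger than the scatter of repeated measurements.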

Compound 4, half-maximal effective concentration: 770 nM
Estimate against measurement, compound 4: 1.3-fold (0.11 log units) below; the range from low to high includes it.
By their numbers in this assay, from the lowest: compounds 1 and 2 (each within the scatter of the next); then compounds 3 and 4 (each within the scatter of the next).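

In this assay, placing 2,5-difluorophenyl where 4-fluorophenyl stood on this saturated ring carbon gives a 1.3-fold higher number from compound 3 to compound 4 (0.11 log units; within the scatter) and leaves compound 3 and compound 4 indistinguishable. Among these compounds, this is the first measured pair to bear on the aromatic group on the three-membered ring, since the only earlier step concerned the amine chain; with this amine chain held fixed, adding a second fluorine and rearranging the fluorine pattern produce no readable difference. Nothing available explains why the two values lie so close together.

This single pair cannot show whether other groups on the same phenyl ring, such as a chlorine, a methoxy group or a nitrile, would also leave the number within the scatter. As far as these compounds go, compound 1 and compound 2 have a plain phenyl and different amine chains, so they differ from compound 3 and compound 4 in more than one place, and it remains open which of those places goes with their much lower numbers.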